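This account rests on a few compounds, and the source may have more. Where it says the series, first, only, none or still open, it means among the compounds named here.

In an assay on cells for inhibition of Indoleamine 2,3-dioxygenase 1 (Homo sapiens), read by HPLC, with a stated time of 20 min (a lower number here means a stronger inhibitor, a higher number a weaker inhibitor), three compounds have been measured so far:

compound 1, `Cn1cncc1-c1ccccc1N`, gives 1700000 nM
compound 2, `Cn1cncc1-c1cc(Cl)ccc1N`, gives 1200000 nM
compound 3, `Oc1ccccc1-c1nnc[nH]1`, gives 31000 nM

Compound 2 differs from compound 1 in one place, (chloro in place of hydrogen on an aromatic carbon). The result of that single change was a 1.4-fold lower number from compound 1 to compound 2 (0.15 log units; within the scatter), so the two compounds cannot be told apart by this assay.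

Compound 3 is built on a different core; the difference between the core of compound 1 and the core of compound 3 is not broken down here. In this assay compound 3 stands well apart from both: its number is lower than that of compound 2 and that of compound 1 by steps that lie beyond the scatter, which makes compound 3 the strongest of the three measured.

Compound 4, `Oc1ccc(Cl)cc1-c1nnc[nH]1`, has not been measured. It differs from compound 3 by chloro in place of hydrogen on an aromatic carbon. For the measured compounds named here, this is the same kind of change as the one from compound 1 to compound 2, but not the same: in compound 1 the entering chloro is meta to a group of 6 heavy atoms and para to an amino group, whereas in compound 3 it is meta to a group of 5 heavy atoms and para to a hydroxy group.

The expectation rests on compound 1 and compound 2, because their step of a 1.4-fold lower number from compound 1 to compound 2 (0.15 log units; within the scatter) stayed within the scatter. For compound 4 the expected step is therefore small, a 1.3-fold lower number from compound 3 to compound 4 (0.11 log units; within the scatter). Compound 4 is thus estimated at 24000 nM, with the likely range from 8000 nM to 70000 nM.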

Compound 4, half-maximal inhibitory concentration: 600 nM
Compound 4: the middle estimate sits 40-fold (1.60 log units) above what was measured; measured number below the stated range.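

In this assay, chloro in place of hydrogen on an aromatic carbon gave a 52-fold lower number from compound 3 to compound 4 (1.71 log units; beyond the scatter), so the change did not carry over at the same size from one core to the other: the same change on two cores in this assay, a 1.4-fold lower number (0.15 log units; within the scatter) from compound 1 to compound 2 and a 52-fold lower number (1.71 log units; beyond the scatter) from compound 3 to compound 4, 36-fold (1.56 log units) apart, beyond the scatter of two such steps

These two pairs therefore show that the size of this step cannot be transferred between the core of compound 1 and the core of compound 3, and that a step read on one of them is a poor guide to the other. They do not show which difference between the cores lies behind the gap, since the entering chloro is para to an amino group on one core and para to a hydroxy group on the other, the meta group also differs, and a single pair on each core cannot separate these features from the rest of the core.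

The compounds shown leave open whether bromo, fluoro or methoxy at the same place on the core of compound 3 would give a step of similar size to that of chloro. They also leave open how the same chloro change would behave on a third core, so no general rule for this series can be drawn yet.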